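Chloro added to the benzoyl ring of compound 2

The compounds below may be only part of what the source reports. "The series", "measured", "known", "first", "only" and "open" are said of these compounds alone.

Working notes on a small series of aminothiophene ketones. Two members have been measured. Compound 1 `Nc1sccc1C(=O)c1ccc(Cl)cc1` carries a chloro group on the benzoyl ring and no substituent on the thiophene; compound 2 `Nc1sc(-c2ccccc2)cc1C(=O)c1ccccc1` carries a phenyl group on the thiophene and a plain benzoyl ring. In an assay on CHO cells for positive allosteric modulation of adenosine receptor A1 (Homo sapiens), read by ERK phosphorylation, tested at 3 uM (a lower number here means a stronger effect, a higher number a weaker effect of the compound at the concentration tested), compound 1 gives 50%. In this assay compound 2 gives 12%, the lowest of the two numbers; compound 1 stands higher by a gap beyond the scatter. Since compounds 1 and 2 differ in two places, no single step can be read from them.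

Compound 3 `Nc1sc(-c2ccccc2)cc1C(=O)c1ccc(Cl)cc1` has not yet been measured. It differs from compound 2 by chloro in place of hydrogen on an aromatic carbon, that is, phenyl to 4-chlorophenyl. Among the measured compounds shown here, no measured pair isolates this change. The step from compound 2 to compound 3 is expected to be a number 8 percentage points higher from compound 2 to compound 3 (within the scatter), a small rise within the scatter. Compound 3 is therefore expected to give 20%, estimated between 5% and 45%.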

Compound 3, a percentage reported as activity, at one concentration (the size of the read-out at that concentration, not a potency): 46%
Beside the measured number, compound 3's estimate is 26 percentage points below it; measured number outside the range, above it.
By their numbers in this assay, from the lowest: compound 2; then compounds 3 and 1 (each within the scatter of the next).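

In this assay, chloro in place of hydrogen on the aromatic carbon para to a large group is not a neutral change: a number 34 percentage points higher from compound 2 to compound 3 (beyond the scatter), a large weakening of the effect at the concentration tested. With the chloro group present, phenyl in place of hydrogen adds little: a number 4 percentage points lower from compound 1 to compound 3 (within the scatter), so in this pair the phenyl group does not restore the strong effect seen for compound 2. Nothing available explains why the chloro group has this effect.

The step for the phenyl group on a benzoyl ring without chloro cannot be read from the compounds shown. On these data alone, whether fluoro, methoxy or an amine at the same place would weaken the effect as chloro does also remains open.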